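The source may hold more compounds than are shown below. What is called first, only, known or untested is meant among the compounds shown, and "the series" means these compounds.

Measured so far:
Compound 1 `O=C(O)CCC/C=C\CC1=CCC[C@@H]1NS(=O)(=O)c1ccccc1`: in a functional assay on a cell-free system (plasma) for inhibition of thromboxane A2 receptor (Homo sapiens), read by turbidimetry (on this read-out higher numbers stand for weaker inhibition and lower numbers for stronger inhibition), compound 1 gives 2300 nM.
Compound 2 `O=C(O)COCCCCC1=CCC[C@@H]1CNS(=O)(=O)c1ccc(F)cc1`: in this assay compound 2 gives 200 nM.

Of these two numbers, compound 1 holds the higher one, and its gap to compound 2 lies beyond the scatter; since the two structures differ in several places, the pair shows only that much. Compound 3 `Cc1ccc(S(=O)(=O)N[C@H]2CCC=C2C/C=C\CCCC(=O)O)cc1` differs from compound 1 by methyl in place of hydrogen on an aromatic carbon. Among the compounds with values here, no measured pair shows this change on its own, so the expectation rests on the change alone. A small step toward a lower number, within or barely beyond the scatter, is expected a 1.5-fold lower number from compound 1 to compound 3 (0.19 log units; within the scatter). Compound 3 is therefore estimated at 1500 nM, between 400 nM and 5000 nM.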

Compound 3, half-maximal inhibitory concentration: 250 nM
The estimate for compound 3 lay 6.0-fold (0.78 log units) above the measured number; the whole stated range lies above it.
By their numbers in this assay, from the lowest: compounds 2 and 3 (each within the scatter of the next); then compound 1.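

In this assay, within the data shown here, the change from phenyl to 4-methylphenyl gives a 9.2-fold lower number from compound 1 to compound 3 (0.96 log units; beyond the scatter) and so provides the first comparison here that differs in one place. It shows that this aromatic carbon, para to a large group, is not indifferent to substitution: one methyl, a single heavy atom, is enough to move the number beyond the scatter. Nothing at hand accounts for the size of this step. As far as these compounds go, whether an ethyl group, a methoxy group or a chlorine atom at this place would give a similar step stays open. So does whether methyl would do the same on another carbon of this ring.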